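Butyl in Place of 3-Ethylphenyl on the Amide Nitrogen

The source may report more compounds than this note shows. Statements on the series, on what has been measured and on what is new or still open speak of the compounds shown alone.

Of the compounds shown here, three in this set have been measured in an ADME assay on SW480 cells (Homo sapiens) for cytotoxicity, read by MTT assay, with a stated time of 72 h; a lower number here means a stronger inhibitor, a higher number a weaker inhibitor. Compound 1 `CCCCCN1C(=O)C/C(=C\c2cccc(C(=O)Nc3ccc(C)cc3)c2)C1=O` gives only a limit of the assay, > 100000 nM, which is the case described by the limit of > 100000 nM in this assay, at which 1 of the 3 values shown sits. Compound 2 `CCc1cccc(NC(=O)c2cccc(/C=C3\CC(=O)N(c4ccccc4)C3=O)c2)c1` gives 88600 nM. Compound 3 `CCCCCN1C(=O)C/C(=C\c2cccc(C(=O)Nc3cccc(CC)c3)c2)C1=O` gives 83300 nM, the lowest of the two numbers, with compound 2 nearest to it and within the scatter. The steps onto compound 3 were small: an at least 1.2-fold lower number from compound 1 to compound 3 (0.07 log units; that floor lies within the scatter) and a 1.1-fold lower number from compound 2 to compound 3 (0.03 log units; within the scatter).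

Compound 4 `CCCCCN1C(=O)C/C(=C\c2cccc(C(=O)NCCCC)c2)C1=O` has not yet been measured. It differs from compound 3 in one place: butyl in place of 3-ethylphenyl on an amide-type nitrogen. Going by the values given here, the step from compound 1 to compound 3 also altered the group on that nitrogen, but kept an aromatic ring there; no measured step exchanges the ring for a chain. Since an at least 1.2-fold lower number from compound 1 to compound 3 (0.07 log units; that floor lies within the scatter) stayed within the scatter, the step expected for compound 4 is a 1.1-fold higher number from compound 3 to compound 4 (0.03 log units; within the scatter), nothing beyond the scatter. Compound 4 is therefore estimated at 90000 nM, with a range from 40000 nM to 200000 nM, and a real chance that this assay again reports only a limit.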

Compound 4, half-maximal inhibitory concentration: > 100000 nM
Compound 4: a limit, no number (the forecaster's own chance of this, stated with the estimate: 40%); middle value at least 1.1-fold (0.04 log units) away from the limit.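

Butyl in place of 3-ethylphenyl, the first exchange of the aromatic ring on this amide-type nitrogen for a chain, gives in this assay an at least 1.2-fold higher number from compound 3 to compound 4 (0.07 log units; that floor lies within the scatter). On these data alone, a chain on this nitrogen therefore brought no gain over the ring, but the size of the change stays unknown, and the step from compound 1 to compound 4 cannot be read. Compound 4 gives a limit and no number, as compound 1 does: the limit of > 100000 nM in this assay, at which 2 of the 4 values shown sit.

The compounds shown leave open how a longer chain such as octyl, or a chain ending in an amine or a carboxylic acid, would read on this nitrogen. Also open, as far as these compounds go, is whether any group here moves the number clearly beyond the scatter.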